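The source may report more compounds than this note shows. Statements on the series, on what has been measured and on what is new or still open speak of the compounds shown alone.

Measured in a functional assay on TREX cells for negative allosteric modulation of metabotropic glutamate receptor 3 (Rattus norvegicus), read by calcium flux, with a stated time of 2.5 min; on this read-out lower numbers stand for stronger inhibition and higher numbers for weaker inhibition:
compound 1 `COc1ccc(C#Cc2ccc(C(=O)N3CCC[C@@H](CO)C3)cc2)c(F)c1` gives > 10000 nM, a limit of the assay rather than a number.
compound 2 `COc1ccc(C#Cc2ccc(C(=O)N3CCCC(OC)C3)cc2)cc1` gives 5500 nM.
compound 3 `COc1ccc(C#Cc2ccc(C(=O)N3CC[C@@H](O)C3)cc2)cc1` gives 10200 nM.

Compound 3 stands highest of the two numbers in this assay; its nearest neighbour is compound 2, and the step of a 1.9-fold higher number from compound 2 to compound 3 (0.27 log units; within the scatter) lies within the scatter. Compound 4 `COc1ccc(C#Cc2ccc(C(=O)N3CCC(CO)C3)cc2)cc1` differs from compound 3 in one place: 3-(hydroxymethyl)pyrrolidin-1-yl in place of 3-hydroxypyrrolidin-1-yl on a carbonyl carbon. Going by the values given here, no measured step alters the substituent on the pyrrolidine itself, so only the step from compound 2 to compound 3, which stayed within the scatter, bears loosely on it. Nothing in the shown numbers points to a shift beyond the scatter in this assay in either direction.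

The step implied by the estimate is expected to be a 1.0-fold lower number from compound 3 to compound 4 (0.01 log units; within the scatter). Compound 4 is estimated at 10000 nM, expected between 4000 nM and 30000 nM.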

Compound 4, half-maximal inhibitory concentration: 7590 nM
Beside the measured number, compound 4's estimate is 1.3-fold (0.12 log units) above it; the measured number falls inside the stated range.
By their numbers in this assay, from the lowest: compounds 2, 4 and 3 (each within the scatter of the next).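

In this assay, exchanging 3-hydroxypyrrolidin-1-yl for 3-(hydroxymethyl)pyrrolidin-1-yl on the carbonyl carbon stays within the scatter (a 1.3-fold lower number from compound 3 to compound 4 (0.13 log units; within the scatter)). Exchanging 3-methoxypiperidin-1-yl for the same group also stays within the scatter (a 1.4-fold higher number from compound 2 to compound 4 (0.14 log units; within the scatter)). Compounds 2, 3 and 4 are therefore not told apart, and this position has so far shown no step beyond the scatter.

From the compounds shown here alone, whether an amine or a carboxylic acid on the pyrrolidine would give such a step remains open. Compound 1 gives a limit of the assay rather than a number: the limit of > 10000 nM in this assay, at which 1 of the 4 values shown sits.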